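The source may hold more compounds than are shown below. What is called first, only, known or untested is meant among the compounds shown, and "the series" means these compounds.

Compound 1 `CCCCCCCc1cc(=O)c2cc(C(F)(F)F)ccc2[nH]1` and compound 2 `CCCCCOCc1cc(=O)c2cc(C(F)(F)F)ccc2[nH]1` share one core, while compound 3 `CCCCCCCc1[nH]c2ccc([N+](=O)[O-])cc2c(=O)c1C(=O)OCC` and the not yet measured compound 4 `CCCCCOCc1[nH]c2ccc([N+](=O)[O-])cc2c(=O)c1C(=O)OCC` share another; how the two cores differ is not broken down here. In a physicochemical assay for solubility, read by HPLC, at pH 7.4 (a lower number here means a less soluble compound, a higher number a more soluble compound), compound 1 gives < 5000 nM, which is a limit of the assay and not a number. In this assay compound 2 gives 15000 nM. The change between them is pentyloxy in place of hexyl on a saturated chain carbon bound to an aromatic carbon, and it produced an at least 3.0-fold higher number from compound 1 to compound 2 (0.47 log units; beyond the scatter); the step is open at its lower end because of the limit of < 5000 nM in this assay, at which 1 of the 3 values shown sits. In this assay compound 3 gives 5000 nM, the lowest of the two numbers shown. Compound 4 carries the same change on the core of compound 3, namely (pentyloxy in place of hexyl on a saturated chain carbon bound to an aromatic carbon), at the same place. Resting on the step seen from compound 1 to compound 2, the same size of step is expected here, so that compound 4 is estimated at 15000 nM, with 7000 nM to 35000 nM as the likely span, meaning an expected 3.0-fold higher number from compound 3 to compound 4 (0.48 log units; beyond the scatter).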

Compound 4, solubility: 15000 nM
The estimate for compound 4 equals the measured number at the digits printed; the measured number falls inside the stated range.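

Carried from one core to the other, pentyloxy in place of hexyl gives a 3.0-fold higher number from compound 3 to compound 4 (0.48 log units; beyond the scatter) in this assay. The number rises on both cores, as it does in an at least 3.0-fold higher number from compound 1 to compound 2 (0.47 log units; beyond the scatter), but this is a finding for these two pairs only and says nothing about any further core. Compound 1 gives < 5000 nM, which is a limit of the assay and not a number, so the first step has no fixed size and the two steps cannot be shown to be equal: the limit of < 5000 nM in this assay, at which 1 of the 4 values shown sits.

Only hexyl and pentyloxy appear on a saturated chain carbon bound to an aromatic carbon, so the compounds shown leave open how an amine, a carboxylic acid or a longer chain at that place would read in this assay. They also leave open whether the change would give a step in the same direction on a core carrying an amide or a nitrile.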